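Chloro in Place of Benzyloxy: Cytotoxicity Notes

The compounds below may be only part of what the source reports. "The series", "measured", "known", "first", "only" and "open" are said of these compounds alone.

compound 1 `Cc1cc(O)c(C(=O)/C=C/c2ccccc2)c(-c2ccc(Br)cc2)c1C(=O)/C=C/c1ccccc1`: 30000 nM
compound 2 `Cc1cc(O)c(C(=O)/C=C/c2ccccc2)c(-c2ccc(OCc3ccccc3)cc2)c1C(=O)/C=C/c1ccccc1`: "not active" (no number reported)

In an ADME assay on HEK293 cells (Homo sapiens) for cytotoxicity, read by MTT assay, with a stated time of 24 h (on this read-out higher numbers stand for weaker inhibition and lower numbers for stronger inhibition), compound 1 gives 30000 nM. Compound 2 stands without a single number; in this assay compound 2 is reported as "not active" (no number reported). Compound 3 `Cc1cc(O)c(C(=O)/C=C/c2ccccc2)c(-c2ccc(Cl)cc2)c1C(=O)/C=C/c1ccccc1` differs from compound 2 by chloro in place of benzyloxy on an aromatic carbon. Within the data shown here, no step between measured compounds is recorded, so the size of this change cannot be read from a measured pair; a move toward a measurable value, nearer to what compound 1 shows at 30000 nM, is expected, since chloro resembles bromo more than benzyloxy. For compound 3 the value in this assay is expected to be 30000 nM, within 12000 nM to 80000 nM.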

Compound 3, half-maximal inhibitory concentration: 5000 nM
For compound 3 the middle estimate is 6.0-fold (0.78 log units) above the measured one; measured number outside the range, below it.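

In this assay this position separates even two halogens: chloro in place of bromo gives a 6.0-fold lower number from compound 1 to compound 3 (0.78 log units; beyond the scatter) on the aromatic carbon para to a large group. Compound 2 is reported as not active and compound 3 gives 5000 nM with the same core, so benzyloxy and chloro stand apart here, although the step between them cannot be read.

Left open is how fluoro, an amine or a carboxylic acid on this carbon would read. No measurement at hand bears on why the two halogens differ.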